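The source may report more compounds than this note shows. Statements on the series, on what has been measured and on what is new or still open speak of the compounds shown alone.

Compound 3 `COc1ccc(-c2cn(-c3ccc(OC)c(O)c3)nn2)cc1` is one of three compounds with an entry in a functional assay on MDA-MB-231 cells (Homo sapiens) for cytotoxicity, read by MTT assay; on this read-out lower numbers stand for stronger inhibition and higher numbers for weaker inhibition. For compound 3 only a limit is reported, and in this assay compound 3 gives > 100 nM. Compound 2 `COc1ccc(-n2cc(-c3ccc(N)cc3)nn2)cc1OC` likewise returns only a limit, and in this assay compound 2 gives > 10000 nM. Compound 1 `COc1ccc(-c2cn(-c3ccc(OC)c(OC)c3)nn2)cc1OC` has no result, its entry in this assay reading "not determined" (no result reported). So compound 3 stands at the limit of > 100 nM in this assay, at which 1 of the 3 values shown sits, whereas compound 2 sits at the limit of > 10000 nM in this assay, at which 1 of the 3 values shown sits; neither is a measured number, and no step between two measured compounds can be drawn from them.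

Compound 4 `COc1ccc(-c2cn(-c3ccc(OC)c(OC)c3)nn2)cc1` is yet to be measured in this assay. It differs from compound 3 by methyl in place of hydrogen on an oxygen on an aromatic ring, which one bond further out reads hydroxy to methoxy. Going by the values given here, with no measured step available for any pair, the size of the change cannot be read from the data; the expectation is therefore of a step no larger than the usual scatter, in no particular direction. On that basis compound 4 is expected to give about 1000 nM, within a range of 200 nM to 10000 nM, so that the estimated step that the limit leaves unreadable from compound 3 to compound 4 stays close to nothing.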

Compound 4, half-maximal inhibitory concentration: > 10000 nM
Compound 4: a limit, no number (the forecaster's own chance of this, stated with the estimate: 50%); middle value at least 10-fold (1.00 log units) from the limit.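

In this assay, going by these compounds alone, compound 2, compound 3 and compound 4 all return limits, so no step from compound 3 or compound 2 to compound 4 can be read. The compounds shown leave open whether hydroxy to methoxy, or methoxy in place of amino on an aromatic carbon, shifts the result in this assay at all, and by how much.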